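Compound 4 after the low number of compound 3

The compounds below may be only part of what the source reports. "The series", "measured", "known", "first", "only" and "open" are said of these compounds alone.

Measured in an ADME assay on HepG2 2.2.15 cells (Homo sapiens) for cytotoxicity, read by luminescence, with a stated time of 3 days; on this read-out lower numbers stand for higher toxicity in this test and higher numbers for lower toxicity in this test:
- compound 1 `O=C(Nc1ccc(F)c(Cl)c1)c1ccc(F)c(S(=O)(=O)N2C[C@H](O)CC[C@H](O)C2)c1`: 25500 nM
- compound 2 `O=C(Nc1ccc(F)c(Cl)c1)c1ccc(F)c(S(=O)(=O)N2CCCCC(O)C2)c1`: 15000 nM
- compound 3 `CC(O)C1CCCCN(S(=O)(=O)c2cc(C(=O)Nc3ccc(F)c(Cl)c3)ccc2F)C1`: 2600 nM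

Compound 3 stands lowest of the three, at 2600 nM. Compound 4 `CC1(O)CCCCN(S(=O)(=O)c2cc(C(=O)Nc3ccc(F)c(Cl)c3)ccc2F)C1` alters it with 3-hydroxy-3-methylazepan-1-yl in place of 3-(1-hydroxyethyl)azepan-1-yl on a sulfonyl sulfur. The closest measured change is 1-hydroxyethyl in place of hydroxy on a saturated ring carbon, a 5.8-fold lower number from compound 2 to compound 3 (0.76 log units; beyond the scatter). The larger 9.8-fold lower number from compound 1 to compound 3 (0.99 log units; beyond the scatter) is also beyond the scatter, whereas a 1.7-fold lower number from compound 1 to compound 2 (0.23 log units; within the scatter) lies within it. Compound 4 gives up the 1-hydroxyethyl, so part of a 5.8-fold lower number from compound 2 to compound 3 (0.76 log units; beyond the scatter) is expected to reverse, as a modest rise in the number. The expected change is a 2.9-fold higher number from compound 3 to compound 4 (0.46 log units; beyond the scatter). The estimate for compound 4 is 7500 nM, with an expected range of 3000 nM to 20000 nM.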

Compound 4, half-maximal cytotoxic concentration: 10000 nM
For compound 4 the middle estimate is 1.3-fold (0.12 log units) below the measured one; measured number inside the range.
By their numbers in this assay, from the lowest: compound 3; then compounds 4, 2 and 1 (each within the scatter of the next, the first and the last beyond it).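

In this assay the 3-hydroxy-3-methylazepan-1-yl on the sulfonyl sulfur gives a 3.8-fold higher number from compound 3 to compound 4 (0.59 log units; beyond the scatter) and so does not share the low number seen with 3-(1-hydroxyethyl)azepan-1-yl. Methyl in place of hydrogen on a saturated ring carbon gives only a 1.5-fold lower number from compound 2 to compound 4 (0.18 log units; within the scatter) while the step from the 3,6-dihydroxyazepan-1-yl, a 2.6-fold lower number from compound 1 to compound 4 (0.41 log units; beyond the scatter) remains beyond the scatter. Nothing available gives a measured reason for these differences.

As far as these compounds go, an amino group in place of the hydroxy remains open, as does an ethyl in place of the methyl.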